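The source may hold more compounds than are shown below. What is called first, only, known or untested is meant among the compounds shown, and "the series" means these compounds.

In a physicochemical assay for solubility (a higher number here means a more soluble compound, a lower number a less soluble compound), compound 1 (`O=C(O)c1cccc(S(=O)(=O)N2CCC(NS(=O)(=O)c3cc(S(=O)(=O)c4ccccc4)ccc3C(F)(F)F)CC2)c1`) gives 12500 nM and compound 2 (`O=C(O)c1ccc(S(=O)(=O)N2CCC(NS(=O)(=O)c3cc(S(=O)(=O)c4ccccc4)ccc3C(F)(F)F)CC2)cc1`) gives 12500 nM while compound 3 (`CC(C)(C)OC(=O)N1CCC[C@@H]1C(=O)N1CCC(NS(=O)(=O)c2cc(S(=O)(=O)c3ccccc3)ccc2C(F)(F)F)CC1`) gives 25000 nM on the same scale. Compound 3 therefore lies within the scatter of both others. Compound 4 (`O=C(CC1CCNCC1)N1CCC(NS(=O)(=O)c2cc(S(=O)(=O)c3ccccc3)ccc2C(F)(F)F)CC1`) differs from it on a carbonyl carbon whose other neighbours are an amide-type nitrogen in a ring, with (piperidin-4-yl)methyl in place of 1-(tert-butoxycarbonyl)pyrrolidin-2-yl ((piperidin-4-yl)methyl in place of 1-(tert-butoxycarbonyl)pyrrolidin-2-yl on a carbonyl carbon). Among the compounds with values here, the single measured step (no change at the digits printed from compound 1 to compound 2 (within the scatter)) lies within the scatter and sits at a different place, on a sulfonyl sulfur, so it bears only indirectly. Within the data shown here, no measured step touches this carbonyl carbon. Compounds 1 and 2 carry carboxyphenyl groups, unlike compound 3, whose 25000 nM nevertheless stays within the scatter of theirs. No step beyond the scatter is therefore expected in this assay for this change. The estimated step is no change at the digits printed from compound 3 to compound 4 (within the scatter) in either direction. For compound 4 the expected value is 25000 nM with an estimated range from 11000 nM to 60000 nM in this measurement.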

Compound 4, solubility: 100000 nM
Beside the measured number, compound 4's estimate is 4.0-fold (0.60 log units) below it, outside the stated range (above it).
By their numbers in this assay, from the lowest: compounds 1, 2 and 3 (each within the scatter of the next); then compound 4.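

In this assay, within the data shown here, the carbonyl carbon whose other neighbours are an amide-type nitrogen in a ring gives the first single-place change here that lies beyond the scatter: (piperidin-4-yl)methyl in place of 1-(tert-butoxycarbonyl)pyrrolidin-2-yl gives a 4.0-fold higher number from compound 3 to compound 4 (0.60 log units; beyond the scatter). Among these compounds, on the amine nitrogen in a ring, ((piperidin-4-yl)methyl)carbonyl gives an 8.0-fold higher number from compound 2 to compound 4 (0.90 log units; beyond the scatter) in place of (4-carboxyphenyl)sulfonyl and an 8.0-fold higher number from compound 1 to compound 4 (0.90 log units; beyond the scatter) in place of (3-carboxyphenyl)sulfonyl, whereas the only earlier step lay within the scatter. No supporting measurement accounts for these steps.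

The entering and leaving groups differ at once in ring size, heavy-atom count and hydrogen-bond donor count, and the compounds shown do not separate these differences. From the compounds shown here alone, it remains open how a pyrrolidin-2-yl group without the tert-butoxycarbonyl group, or a piperidin-4-yl group without the methylene link, would read at this carbonyl carbon.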